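A few compounds are considered here, and "the series" means these few. Any claim that something is new, unique, unknown or untested is made for them only; others in the source may bear on it.

Working notes on the lactone series.

Compound 1 `O=C1C[C@H](O)C[C@@H](/C=C/c2c(Cl)cc(Cl)cc2-c2cc(Cl)cc(Cl)c2)O1` is the reference point. Among the measured compounds shown here, in an assay for inhibition of 3-hydroxy-3-methylglutaryl-coenzyme A reductase (Rattus norvegicus) (on this read-out higher numbers stand for weaker inhibition and lower numbers for stronger inhibition), compound 1 gives 37 nM, the lowest number among the three measured members; the nearest is compound 3, the furthest compound 2. Compound 3 `O=C1C[C@H](O)C[C@@H](/C=C/c2c(Cl)cc(Cl)cc2-c2ccccc2)O1` carries phenyl in place of the 3,5-dichlorophenyl of compound 1; in this assay compound 3 gives 80 nM, and the resulting change is a 2.2-fold higher number from compound 1 to compound 3 (0.33 log units; beyond the scatter). Compound 2 `O=C1C[C@H](O)CC(CCc2c(Cl)cc(Cl)cc2-c2ccccc2)O1` has the same phenyl and a saturated two-carbon link to the core; in this assay compound 2 gives 100 nM, with no single-change comparison to compound 1 available.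

Compound 4 `O=C1C[C@H](O)C[C@@H](/C=C/c2c(Cl)cc(Cl)cc2-c2ccc(Cl)c(Cl)c2)O1` differs from compound 1 by 3,4-dichlorophenyl in place of 3,5-dichlorophenyl on an aromatic carbon. For the measured compounds named here, the only measured step bearing on this position is the one from compound 1 to compound 3, which shows that removing both chloro groups from the distal ring costs a modest amount. Compound 4 retains both chloro groups, merely relocated, so the pattern gives no clear expectation of a change beyond the scatter; a small loss is judged somewhat more likely than a gain, because compound 1 gives 37 nM with the 3,5-dichlorophenyl in place. The expected step is therefore a 1.4-fold higher number from compound 1 to compound 4 (0.13 log units; within the scatter), and compound 4 is estimated at 50 nM with a range from 20 nM to 130 nM.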

Compound 4, half-maximal inhibitory concentration: 25 nM
Compound 4: the middle estimate sits 2.0-fold (0.30 log units) above what was measured; low and high end bracket the measured number.
By their numbers in this assay, from the lowest: compounds 4 and 1 (each within the scatter of the next); then compounds 3 and 2 (each within the scatter of the next).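

The new compound shows that, in this assay, this position tolerates a change in the arrangement of the two chloro groups: 3,4-dichlorophenyl and 3,5-dichlorophenyl cannot be told apart (a 1.5-fold lower number from compound 1 to compound 4 (0.17 log units; within the scatter)). It also gives a second comparison with the unsubstituted phenyl (a 3.2-fold lower number from compound 3 to compound 4 (0.51 log units; beyond the scatter)), which points the same way as the earlier step (a 2.2-fold higher number from compound 1 to compound 3 (0.33 log units; beyond the scatter)), so among compounds 1, 3 and 4 both dichlorophenyl groups give lower numbers than phenyl, and no listed compound at this position goes against that. Nothing available accounts for the result or explains the difference from phenyl.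

Still open, as far as these compounds go, is whether both chloro groups are needed, or whether a single chloro group, a methoxy group, an amine or a carboxylic acid on this ring would give a number like those of compound 1 and compound 4. Also open, from the compounds shown here alone, is whether the 3,4-dichlorophenyl group would behave the same way on the saturated two-carbon link of compound 2.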